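Chain extension from compound 3 to compound 4

A few compounds are considered here, and "the series" means these few. Any claim that something is new, unique, unknown or untested is made for them only; others in the source may bear on it.

Within the data shown here, in a physicochemical assay for lipophilicity (on this read-out lower numbers stand for lower lipophilicity and higher numbers for higher lipophilicity), compound 3 `CCCCOC(=O)c1ccccc1S(N)(=O)=O` gives 2.01 as the highest of the three numbers so far. Compound 2 `CCCOC(=O)c1ccccc1S(N)(=O)=O` stands lower at 1.49 and compound 1 `CCCNC(=O)c1ccc(S(N)(=O)=O)cc1` lower still at 0.51 with both gaps to compound 3 beyond the scatter. The change to compound 4 `CCCCCOC(=O)c1ccccc1S(N)(=O)=O` is methyl in place of hydrogen on a saturated chain carbon, four bonds along the chain from an oxygen next to a carbonyl group and reads as methyl in place of hydrogen on a saturated chain carbon, four bonds along the chain from an oxygen next to a carbonyl group. Among the measured compounds shown here, the one measured step of this kind is a number 0.52 log units higher from compound 2 to compound 3 (beyond the scatter) for the same replacement three bonds along the chain. A rise of similar size is therefore expected in this assay and is estimated as a number 0.52 log units higher from compound 3 to compound 4 (beyond the scatter) on that single step. Compound 4 is estimated at 2.53 (expected range 2.25 to 2.8).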

Compound 4, partition coefficient: 2.55
Beside the measured number, compound 4's estimate is 0.02 log units below it, and the stated range covers the measured number.
By their numbers in this assay, from the lowest: compound 1; then compound 2; then compound 3; then compound 4.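

In this assay this change now has a second reading one bond further out, with a number 0.54 log units higher from compound 3 to compound 4 (beyond the scatter) and, one bond nearer, a number 0.52 log units higher from compound 2 to compound 3 (beyond the scatter) as the earlier modest step. The two together give a number 1.06 log units higher from compound 2 to compound 4 (beyond the scatter) and so, across compound 2, compound 3 and compound 4, each added methyl brings a rise of similar size, with none of the three going against this. No evidence on hand bears on the reason for this rise. On these data alone, whether a longer chain continues the same way stays open, as does what an amine or a carboxylic acid in place of the added methyl would read.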